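This account rests on a few compounds, and the source may have more. Where it says the series, first, only, none or still open, it means among the compounds named here.

Compound 1 `NCc1ccccc1CN(Cc1nc2ccccc2[nH]1)C1CCCc2cccnc21`: 28 nM in a functional assay on CEM-CCRF cells for antagonist activity at C-X-C chemokine receptor type 4 (Homo sapiens), read by calcium flux; a higher number here means a weaker inhibitor, a lower number a stronger inhibitor.
Compound 2 `NCc1ccncc1CN(Cc1nc2ccccc2[nH]1)C1CCCc2cccnc21`: 160 nM in this assay.
Compound 3 `NCc1sccc1CN(Cc1nc2ccccc2[nH]1)C1CCCc2cccnc21`: 60 nM in this assay.

Three compounds share one core and differ only in the aromatic ring carried on the saturated chain carbon bound to the amine nitrogen. Compound 3 stands second highest of the three numbers: its nearest neighbour is compound 1, with a 2.1-fold higher number from compound 1 to compound 3 (0.33 log units; beyond the scatter), and its furthest is compound 2, with a 2.7-fold lower number from compound 2 to compound 3 (0.43 log units; beyond the scatter). The swap of rings from compound 1 to compound 2 gave a 5.7-fold higher number from compound 1 to compound 2 (0.76 log units; beyond the scatter).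

Compound 4 `NCc1cscc1N(Cc1nc2ccccc2[nH]1)C1CCCc2cccnc21` differs from compound 3 in another way: a group of 7 heavy atoms (5 carbon, 1 nitrogen, 1 sulfur; one five-membered aromatic ring with 1 hetero atom) in place of a group of 8 heavy atoms (6 carbon, 1 nitrogen, 1 sulfur; one five-membered aromatic ring with 1 hetero atom), on an amine nitrogen. The aromatic ring thereby moves from the saturated chain carbon onto the amine nitrogen itself. For the measured compounds named here, none of the measured steps touches that linkage; all three only exchange one ring for another while keeping the same attachment. So no step measured here bears directly on this change, and the expectation rests on the general observation that every ring swap so far shifted the number only modestly, while a change in how the ring is attached is a larger structural alteration.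

Compound 4 is therefore expected to be a weaker inhibitor than compound 3, with an estimated step of a 5.0-fold higher number from compound 3 to compound 4 (0.70 log units; beyond the scatter). Compound 4 is estimated at 300 nM in this assay, with a range from 60 nM to 2000 nM.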

Compound 4, half-maximal inhibitory concentration: 13 nM
Beside the measured number, compound 4's estimate is 23-fold (1.36 log units) above it; measured number below the stated range.
By their numbers in this assay, from the lowest: compound 4; then compound 1; then compound 3; then compound 2.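

Moving the five-membered aromatic ring from the saturated chain carbon directly onto the amine nitrogen gave a 4.6-fold lower number from compound 3 to compound 4 (0.66 log units; beyond the scatter) in this assay, so this position accepts the loss of that chain carbon and even improves on it. The comparisons with the two six-membered rings read a 2.2-fold lower number from compound 1 to compound 4 (0.33 log units; beyond the scatter) and a 12-fold lower number from compound 2 to compound 4 (1.09 log units; beyond the scatter), which makes compound 4 the strongest inhibitor of the four, though each of these steps changes the ring and its attachment together. No measurement here accounts for the improvement.

The compounds shown leave open whether a six-membered aromatic ring of carbon only would also improve when attached directly to the amine nitrogen. They also leave open how the activity would respond if the ring's aminomethyl group gave way to a longer amine chain or a carboxylic acid.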